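Chloro for methoxy on the pendant phenyl ring

This account rests on a few compounds, and the source may have more. Where it says the series, first, only, none or still open, it means among the compounds named here.

Compound 1 `COc1ccc(-c2cc(=O)c3c(O)cc(OCCCCN4CCN(C)CC4)c(OC)c3o2)cc1` holds the higher of the two measured numbers: in a functional assay on HepG2 cells (Homo sapiens) for cytotoxicity, read by MTT assay, with a stated time of 72 h (on this read-out lower numbers stand for stronger inhibition and higher numbers for weaker inhibition), compound 1 gives 4200 nM. For the measured compounds named here, its only measured neighbour, compound 2 `COc1c(OCCCCN2CCN(C)CC2)cc(O)c2c(=O)cc(-c3ccc(C)cc3)oc12`, differs by methyl in place of methoxy on an aromatic carbon, and compound 2 gives 1000 nM, a step of a 4.2-fold lower number from compound 1 to compound 2 (0.62 log units; beyond the scatter). Compound 3 `COc1c(OCCCCN2CCN(C)CC2)cc(O)c2c(=O)cc(-c3ccc(Cl)cc3)oc12` carries instead (chloro in place of methoxy on an aromatic carbon), the same difference cut one bond further out reading 4-methoxyphenyl to 4-chlorophenyl. Because the neighbouring exchange gave a 4.2-fold lower number from compound 1 to compound 2 (0.62 log units; beyond the scatter), a modest drop of similar size is expected here, a 2.8-fold lower number from compound 1 to compound 3 (0.45 log units; beyond the scatter). Compound 3 is therefore estimated at 1500 nM, within a range from 500 nM to 4500 nM.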

Compound 3, half-maximal inhibitory concentration: 3750 nM
Beside the measured number, compound 3's estimate is 2.5-fold (0.40 log units) below it; the range from low to high includes it.
By their numbers in this assay, from the lowest: compound 2; then compounds 3 and 1 (each within the scatter of the next).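

In this assay, chloro and methoxy on the pendant phenyl ring cannot be told apart, with a 1.1-fold lower number from compound 1 to compound 3 (0.05 log units; within the scatter) for this exchange. Methyl alone stands apart among the three groups at this position, with a 3.8-fold higher number from compound 2 to compound 3 (0.57 log units; beyond the scatter) in the sense that lowering the number from compound 1 does not extend to every replacement of methoxy. Nothing measured bears on the reason for this difference. As far as these compounds go, whether fluoro, ethyl or an amine at this position would read with methyl or with chloro stays open.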